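A few compounds are considered here, and "the series" means these few. Any claim that something is new, unique, unknown or untested is made for them only; others in the source may bear on it.

Measured compounds:
Compound 1, `CCCCCCCC/C=C/CCCCCCCC(=O)Nc1ccccc1OC`: 8000 nM
Compound 2, `CCCCCCCC/C=C/CCCCCCCC(=O)Nc1cc(C(=O)OC)ccc1OC`: 430 nM

Within the data shown here, of the two numbers recorded in an assay on microsomes from intestine for inhibition of acyl-CoA:cholesterol acyltransferase (Oryctolagus cuniculus) (a higher number here means a weaker inhibitor, a lower number a stronger inhibitor), compound 1 stands at the highest; its nearest neighbour is compound 2, reached by a 19-fold lower number from compound 1 to compound 2 (1.27 log units; beyond the scatter), the only step measured so far. The compound still to be measured is compound 3, `CCCCCCCC/C=C/CCCCCCCC(=O)Nc1cccc(C)c1[N+](=O)[O-]`. It differs from compound 1 by 3-methyl-2-nitrophenyl in place of 2-methoxyphenyl on an amide-type nitrogen. Among the measured compounds shown here, no measured step covers this exchange: the known step from compound 1 to compound 2 added a methoxycarbonyl group while the methoxy remained, whereas here the methoxy itself leaves and a methyl and a nitro group enter. That step shows the read-out in this assay can shift strongly with a ring substituent, but gives no direction for the present change. A modest move is therefore expected, taken as a 2.7-fold lower number from compound 1 to compound 3 (0.43 log units; beyond the scatter). For compound 3 the estimate is 3000 nM with a range from 800 nM to 15000 nM.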

Compound 3, half-maximal inhibitory concentration: 12000 nM
Estimate against measurement, compound 3: 4.0-fold (0.60 log units) below; the range from low to high includes it.
By their numbers in this assay, from the lowest: compound 2; then compounds 1 and 3 (each within the scatter of the next).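

In this assay, exchanging the whole aryl group on the amide-type nitrogen gives a 1.5-fold higher number from compound 1 to compound 3 (0.18 log units; within the scatter), so compound 1 and compound 3 cannot be told apart. The methoxy group can therefore leave, with a methyl and a nitro group entering, without a resolved shift at this position, whereas the methoxycarbonyl addition gave a 19-fold lower number from compound 1 to compound 2 (1.27 log units; beyond the scatter). No evidence at hand bears on the reason for this contrast.

As far as these compounds go, the separate contributions of the methyl and the nitro group remain open, as does whether adding methoxycarbonyl to the 3-methyl-2-nitrophenyl ring would give a shift like that seen with the 2-methoxyphenyl ring. Also open, from the compounds shown here alone, is how a carboxylic acid or an amine would read in place of the methoxycarbonyl group on the 2-methoxyphenyl ring.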